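Extending the Chain of Compound 1 with Decyl

A few compounds are considered here, and "the series" means these few. Any claim that something is new, unique, unknown or untested is made for them only; others in the source may bear on it.

Measured in a functional assay on the whole organism with Mus musculus as the target, in the rotarod test; on this read-out lower numbers stand for an effect already at smaller amounts and higher numbers for an effect only at larger amounts of compound:
- compound 1 `CCCCCC(=O)NCC(=O)N(C)c1ccc(Cl)cc1C(=O)c1ccccc1Cl` gives 90 mg/kg
- compound 2 `CC(C)NCC(=O)NCC(=O)N(C)c1ccc(Cl)cc1C(=O)c1ccccc1Cl` gives 13 mg/kg
- compound 3 `CCN(CC)CC(=O)NCC(=O)N(C)c1ccc(Cl)cc1C(=O)c1ccccc1Cl` gives 34 mg/kg

Compound 4 `CCCCCCCCCCCCCCCC(=O)NCC(=O)N(C)c1ccc(Cl)cc1C(=O)c1ccccc1Cl` has not yet been measured. Compound 1 has the highest number of the three, so it needs the largest dose for an effect. Compound 4 differs from it in one place: decyl in place of hydrogen on a saturated chain carbon, five bonds along the chain from a carbonyl carbon. In words, this is decyl in place of hydrogen on a saturated chain carbon, five bonds along the chain from a carbonyl carbon.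

Within the data shown here, no measured step lengthens a chain, so the evidence is indirect. The closest steps change the same end of the chain, replacing butyl. Isopropylamino gave a 6.9-fold lower number from compound 1 to compound 2 (0.84 log units; beyond the scatter), and diethylamino gave a 2.6-fold lower number from compound 1 to compound 3 (0.42 log units; beyond the scatter). The two amino groups also differ from each other, with a 2.6-fold higher number from compound 2 to compound 3 (0.42 log units; beyond the scatter). Among the measured compounds shown here, both replacements of the plain butyl lowered the number, and no measured compound goes against this, though three compounds are a thin basis. A modest move towards a higher number is therefore expected on extending the plain chain, with wide uncertainty. The estimated change is a 2.2-fold higher number from compound 1 to compound 4 (0.35 log units; beyond the scatter). For compound 4 the expected value is 200 mg/kg, with an estimated range from 70 mg/kg to 600 mg/kg.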

Compound 4, dose for half-maximal effect: > 100 mg/kg
Compound 4 gave a limit, no number (the forecaster's own chance of this, stated with the estimate: 30%); the middle value lies beyond the limit too.
By their numbers in this assay, from the lowest: compound 2; then compound 3; then compound 1. At a limit, above all of these: compound 4.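

In this assay, compound 4 returns a limit and not a number: the limit of > 100 mg/kg in this assay, at which 1 of the 4 values shown sits.

Decyl in place of hydrogen on a saturated chain carbon, five bonds along the chain from a carbonyl carbon, gives an at least 1.1-fold higher number from compound 1 to compound 4 (0.04 log units; that floor lies within the scatter), so this step cannot show a real gap between the two compounds. Among these compounds, what it adds is a first look at a much longer plain carbon chain at this end of the molecule: the earlier steps from compound 1 brought in amino groups and both lowered the number, whereas the long chain shows no such drop.

On these data alone, how far past its limit compound 4 really lies stays unknown, so the true size of this step cannot be read, and neither can the effect of chain length taken on its own. Also open, as far as these compounds go, is whether a plain chain of middle length such as hexyl would behave like butyl or like the long chain, and whether a ring amine such as morpholine in place of butyl would carry on the lowering seen with the two amino groups.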